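Bromo to hydrogen at the methyl-flanked ring position

The source may hold more compounds than are shown below. What is called first, only, known or untested is meant among the compounds shown, and "the series" means these compounds.

Measured so far, in an assay on HEK293 cells for inhibition of Lysophosphatidylserine lipase ABHD12 (Homo sapiens), read by scintillation counting, with stated times of 30 min and 5 min; on this read-out higher numbers stand for weaker inhibition and lower numbers for stronger inhibition:
compound 1 `COc1ccc(-c2cc(C(=O)NC3CCCCCC3)c(OCc3ccc(F)cc3)nc2C)cc1`: > 10000 nM
compound 2 `Cc1nc(OCc2ccc(F)cc2)c(C(=O)NC2CCCCCC2)cc1Br`: 2100 nM

Compound 2 gives 2100 nM in this assay, the only actual number shown. For compound 1 the reading > 10000 nM is a limit of the assay (the limit of > 10000 nM in this assay, at which 1 of the 2 values shown sits). For the measured compounds named here, the single measured step, an at least 4.7-fold lower number from compound 1 to compound 2 (0.67 log units; beyond the scatter), shows that this ring position responds to what sits on it.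

Compound 3 `Cc1ccc(C(=O)NC2CCCCCC2)c(OCc2ccc(F)cc2)n1` differs from compound 2 by hydrogen in place of bromo on an aromatic carbon. Going by the values given here, no measured step exchanges bromo for hydrogen, so direction is open; a modest weakening is expected, a 2.1-fold higher number from compound 2 to compound 3 (0.33 log units; beyond the scatter). Compound 3 is estimated at 4500 nM, range 1500 nM to 13000 nM, with a real chance of a limit only.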

Compound 3, half-maximal inhibitory concentration: > 10000 nM
Compound 3 was reported as a limit; the forecaster's own chance of this, stated with the estimate: 30%; middle value at least 2.2-fold (0.34 log units) away from the limit.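

Replacing bromo with hydrogen on this aromatic carbon gives an at least 4.7-fold higher number from compound 2 to compound 3 (0.67 log units; beyond the scatter), so among the compounds shown only bromo at this position yields a measured number, and neither hydrogen nor 4-methoxyphenyl does. The reading for compound 3, > 10000 nM, is a limit of the assay. The step from compound 1 to compound 3 cannot be read, as both readings are limits.

On these data alone, the order of hydrogen and 4-methoxyphenyl at this position stays open. Also open, as far as these compounds go, is whether chloro, methyl or a nitrile here would match bromo.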